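Compound 3 to compound 4: a cyclobutyl swap

A few compounds are considered here, and "the series" means these few. Any claim that something is new, unique, unknown or untested is made for them only; others in the source may bear on it.

Compound 1 `CSc1cccc(N(C(=O)c2cc3ccc(C(F)(F)F)cc3[nH]2)[C@@H](C)C(=O)NC2CCCC2)c1` gives 7100 nM
Compound 2 `CSc1cccc(N2C(=O)CN(c3cncc(C(F)(F)F)c3)CC2C(=O)NC2CCCC2)c1` gives > 50000 nM (a limit)
Compound 3 `O=C(NCC1CC1)C1CN(c2ccccc2)CC(=O)N1c1ccc2ccsc2c1` gives > 50000 nM (a limit)

In an ADME assay on HepG2 cells (Homo sapiens) for cytotoxicity (a higher number here means that more compound is tolerated, a lower number that less compound is tolerated), compound 3 gives > 50000 nM, which is a limit and not a number. Compound 3 thus belongs with compound 2 at the limit of > 50000 nM in this assay, at which 2 of the 3 values shown sit. Compound 1 gives 7100 nM and alone has a true number.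

Compound 4 `O=C(NC1CCC1)C1CN(c2ccccc2)CC(=O)N1c1ccc2ccsc2c1` carries cyclobutyl in place of cyclopropylmethyl on an amide-type nitrogen, the same atoms joined differently. Within the data shown here, no measured pair shows this change. In this assay the expected result is no step beyond the usual scatter, estimated as an at least 1.2-fold lower number from compound 3 to compound 4 (0.09 log units; that floor lies within the scatter). For compound 4 the estimated value is 40000 nM, with an expected range from 15000 nM to 50000 nM, and a result at the limit again is likely.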

Compound 4, half-maximal cytotoxic concentration: > 50000 nM
Compound 4 was reported as a limit; the forecaster's own chance of this, stated with the estimate: 75%; at least 1.2-fold (0.09 log units) between middle value and limit.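

Compound 3 and compound 4 are both reported only as limits in this assay, so no step can be read between them: the limit of > 50000 nM in this assay, at which 3 of the 4 values shown sit.

On these data alone, whether cyclobutyl in place of cyclopropylmethyl changes how much compound is tolerated stays open.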